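The source may hold more compounds than are shown below. What is called first, only, known or untested is meant among the compounds shown, and "the series" means these compounds.

In a functional assay with Cavia porcellus as the target (on this read-out higher numbers stand for weaker inhibition and lower numbers for stronger inhibition), three compounds have been measured. Compound 1 `C=CC[N+](C)(C)c1cccc(O)c1` gives 13000 nM. Compound 3 `C=CC[N+](C)(C)c1ccccc1OC` gives 2890 nM. For compound 2 `C=CC[N+](C)(C)c1ccc(O)cc1` the read-out is a limit of the assay rather than a number, > 3000 nM, so compound 2 stands at the limit of > 3000 nM in this assay, at which 1 of the 3 values shown sits. Compound 4 `C=CC[N+](C)(C)c1ccc(OC)cc1` has not yet been measured in this assay; it differs from compound 2 by methyl in place of hydrogen on an oxygen on an aromatic ring. Within the data shown here, no two measured compounds differ in only one place, so no measured step guides this change directly. The step is expected to be modest, a step that the limit leaves unreadable from compound 2 to compound 4, since compound 3 with 2890 nM already carries a methoxy group and sits at the stronger end of the measured values. Compound 4 is estimated to give 5000 nM, with a likely range from 1500 nM to 20000 nM.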

Compound 4, half-maximal inhibitory concentration: > 3000 nM
Compound 4: a limit, no number (the forecaster's own chance of this, stated with the estimate: 40%); the middle value is on the limit's open side.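

Compound 2 and compound 4 both end at a limit of the assay, so no step from hydroxy to methoxy can be read between them: the limit of > 3000 nM in this assay, at which 2 of the 4 values shown sit.

The compounds shown leave open how much this change alters inhibition in this assay.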